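Permeability notes: benzylamine swap carried onto a second core

A few compounds are considered here, and "the series" means these few. Any claim that something is new, unique, unknown or untested is made for them only; others in the source may bear on it.

Measured so far in an ADME assay for permeability, using PAMPA, with a stated time of 30 min, at pH 7.4; a lower number here means that the compound crosses the layer more slowly, a higher number that the compound crosses the layer faster:
compound 1 `COc1cccc(Oc2ccc3c(NCCCNCc4ccco4)ccnc3c2)c1` gives 317 10^-6 cm/s
compound 2 `COc1cccc(Oc2ccc3c(NCCCNCc4cccc(OC)c4O)ccnc3c2)c1` gives 317 10^-6 cm/s
compound 3 `Fc1ccc(Cc2ccc3c(NCCCNCc4ccco4)ccnc3c2)cc1` gives 23 10^-6 cm/s

Compound 1 and compound 2 share one core and differ by 2-hydroxy-3-methoxyphenyl in place of furan-2-yl on a saturated chain carbon bound to an amine nitrogen; the step of no change at the digits printed from compound 1 to compound 2 (within the scatter). Compound 3 carries a different core, and the difference between the two cores is 4-fluorobenzyl in place of 3-methoxyphenoxy on an aromatic carbon; the step of a 14-fold lower number from compound 1 to compound 3 (1.14 log units; beyond the scatter), so compound 3 stands well apart from the first two.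

Compound 4 `COc1cccc(CNCCCNc2ccnc3cc(Cc4ccc(F)cc4)ccc23)c1O` is not yet measured. It differs from compound 3 by 2-hydroxy-3-methoxyphenyl in place of furan-2-yl on a saturated chain carbon bound to an amine nitrogen, the same change as from compound 1 to compound 2, at the same place. Among the measured compounds shown here, the only precedent is the step from compound 1 to compound 2, which stayed within the scatter, so the expectation is that compound 4 moves little from compound 3, with the step estimated as no change at the digits printed from compound 3 to compound 4 (within the scatter). On this basis compound 4 is expected to give about 23 10^-6 cm/s, estimated between 10 10^-6 cm/s and 50 10^-6 cm/s. A single precedent on a different core is a thin basis, and the measurement will show whether the swap behaves alike on both cores.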

Compound 4, apparent permeability: 23 10^-6 cm/s
Compound 4: middle estimate and measured number agree at the digits printed, within the range that was stated.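

In this assay, 2-hydroxy-3-methoxyphenyl in place of furan-2-yl gives no change at the digits printed from compound 3 to compound 4 (within the scatter), and the swap carries over from the core of compound 1 to the core of compound 3 without a detectable difference: the same change on two cores in this assay, no change at the digits printed (within the scatter) from compound 1 to compound 2 and no change at the digits printed (within the scatter) from compound 3 to compound 4, 1.0-fold (0.00 log units) apart, within the scatter of two such steps The core change, 4-fluorobenzyl in place of 3-methoxyphenoxy on an aromatic carbon, gives a 14-fold lower number from compound 2 to compound 4 (1.14 log units; beyond the scatter), and its size holds with either group on the chain: the same change on two cores in this assay, a 14-fold lower number (1.14 log units; beyond the scatter) from compound 1 to compound 3 and a 14-fold lower number (1.14 log units; beyond the scatter) from compound 2 to compound 4, 1.0-fold (0.00 log units) apart, within the scatter of two such steps Two cores and one pair of groups are a narrow base, so this does not show that the swap would stay silent on any further core or with other groups, and it gives no reason for the size of the core step.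

Left open is whether the result holds with a pyridine or an unsubstituted phenyl in place of 2-hydroxy-3-methoxyphenyl, or with a longer chain in place of the present one. Also open, as far as these compounds go, is how a carboxylic acid or an amide on that aromatic carbon, in place of 4-fluorobenzyl, would read in this assay.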